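One More Methoxy Group: What to Expect for Compound 4

The source may report more compounds than this note shows. Statements on the series, on what has been measured and on what is new or still open speak of the compounds shown alone.

Measured so far:
compound 1 `COc1ccc(-c2cc(/C=C/C(=O)c3cc(OC)c(OC)c(OC)c3)[nH]n2)cc1OC` gives 6090 nM
compound 2 `COc1ccc(-c2cc(/C=C/C(=O)c3ccc(N)cc3)[nH]n2)cc1` gives 6170 nM
compound 3 `COc1ccc(C(=O)/C=C/c2cc(-c3cc(OC)c(OC)c(OC)c3)n[nH]2)cc1` gives 6480 nM

In a functional assay on HCC 2998 cells (Homo sapiens) for inhibition, read by sulforhodamine B assay, with a stated time of 48 h (a lower number here means that less compound is tolerated, a higher number that more compound is tolerated), compound 1 gives 6090 nM, the lowest of the three numbers, but compound 2 and compound 3 both lie within the scatter of it, so the three compounds cannot be told apart on these data. Compound 4 `COc1cc(C(=O)/C=C/c2cc(-c3cc(OC)c(OC)c(OC)c3)n[nH]2)cc(OC)c1OC` has not been measured. It differs from compound 1 in one place: methoxy in place of hydrogen on an aromatic carbon. For the measured compounds named here, no measured pair shows this change on its own, so its size is unknown; the three measured compounds, all carrying methoxy groups in varied numbers, sit together within the scatter. The step from compound 1 to compound 4 is therefore expected to be a 1.0-fold lower number from compound 1 to compound 4 (0.01 log units; within the scatter), none beyond the scatter. Compound 4 is estimated at 6000 nM, with a range from 3000 nM to 12000 nM.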

Compound 4, concentration lethal to 50% of the cells: 6310 nM
Compound 4: the middle estimate sits 1.1-fold (0.02 log units) below what was measured; the range from low to high includes it.
By their numbers in this assay, from the lowest: compounds 1, 2, 4 and 3 (each within the scatter of the next).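

Methoxy in place of hydrogen on this aromatic carbon, ortho to a methoxy group, now has a measured size: in this assay the change gives a 1.0-fold higher number from compound 1 to compound 4 (0.02 log units; within the scatter). On the core of compound 1, then, this added methoxy group produces no difference that the assay can separate from repeat-measurement noise. As far as these compounds go, whether a carboxylic acid, an amine or a longer chain such as butoxy on this same carbon would move the number beyond the scatter remains open. Nothing measured here speaks to why this step is so small.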